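The source may hold more compounds than are shown below. What is called first, only, known or untested is meant among the compounds shown, and "the series" means these compounds.

The measured compounds:

compound 1, `C=CC[C@H]1C[C@]2([C@@H](C)Cc3ccc(OC)c(C)c3)OCOC2=CC1=O`, 410 nM
compound 2, `C=CC[C@H]1C[C@]2([C@@H](C)Cc3cc(C)c(OC)cc3F)OCOC2=CC1=O`, 230 nM
compound 3, `C=CC[C@H]1C[C@]2([C@@H](C)Cc3ccc(OC)cc3F)OCOC2=CC1=O`, 14 nM

All three were tested in a functional assay on M14 cells (Homo sapiens) for antiproliferative activity, with a stated time of 72 h; on this read-out higher numbers stand for weaker inhibition and lower numbers for stronger inhibition. Compound 2 differs from compound 1 by fluoro in place of hydrogen on an aromatic carbon, and the step of a 1.8-fold lower number from compound 1 to compound 2 (0.25 log units; within the scatter). Compound 3 differs from compound 2 by hydrogen in place of methyl on an aromatic carbon, and here the step of a 16-fold lower number from compound 2 to compound 3 (1.22 log units; beyond the scatter). Compound 3 stands lowest of the three, and its steps to both compound 1 and compound 2 lie beyond the scatter. The difference between the cores of compound 1 and compound 3 is not broken down here.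

Compound 4, `C=CC[C@H]1C[C@]2([C@@H](C)Cc3cc(F)c(OC)cc3F)OCOC2=CC1=O`, has not yet been measured in this assay. It differs from compound 3 by fluoro in place of hydrogen on an aromatic carbon. Among the compounds with values here, this is the same kind of change as the one from compound 1 to compound 2, but not the same: in that earlier pair the new fluoro sat ortho to a large group, meta to a methoxy group and para to a methyl group, whereas in compound 4 it sits ortho to a methoxy group, meta to a large group and para to a fluoro group.

The step expected from this change is a 1.3-fold lower number from compound 3 to compound 4 (0.10 log units; within the scatter), set beside the earlier one, which is small because a 1.8-fold lower number from compound 1 to compound 2 (0.25 log units; within the scatter) stayed within the scatter. Compound 4 is therefore estimated at 11 nM, with a range from 4 nM to 35 nM.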

Compound 4, half-maximal inhibitory concentration: 30 nM
For compound 4 the middle estimate is 2.7-fold (0.44 log units) below the measured one; measured number inside the range.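

In this assay the new fluoro gave a 2.1-fold higher number from compound 3 to compound 4 (0.33 log units; beyond the scatter), so compound 3 at 14 nM stays the lowest of the four compounds, and replacing the methyl by fluoro gave a 7.7-fold lower number from compound 2 to compound 4 (0.88 log units; beyond the scatter). Fluoro in place of hydrogen on an aromatic carbon therefore did not carry over from one core to the other with the same result, as the two steps differ: the same change on two cores in this assay, a 1.8-fold lower number (0.25 log units; within the scatter) from compound 1 to compound 2 and a 2.1-fold higher number (0.33 log units; beyond the scatter) from compound 3 to compound 4, 3.8-fold (0.58 log units) apart, beyond the scatter of two such steps. Within the data shown here, this does not yield a rule for the change, since there are only two pairs, the first of the two steps lies within the scatter, and the pairs differ both in their cores and in where the fluoro sits on the aromatic ring, so these compounds cannot separate the contributions of those differences.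

Going by these compounds, what a chloro or trifluoromethyl group would do on the same aromatic carbon remains open, and so does whether fluoro in the other places on this ring would give a step of the same direction. All four compounds also keep the methoxy group and the allyl chain, which leaves open how this change would behave with a hydroxy group in place of the methoxy or with a longer chain in place of the allyl.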